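Amide substituent change in a cytotoxicity series

The source may hold more compounds than are shown below. What is called first, only, known or untested is meant among the compounds shown, and "the series" means these compounds.

Measured so far:
- compound 1, `N[C@H]1CC[C@H](Nc2c(C(=O)NCc3ccc(Cl)cc3)nc(Br)c3cccnc23)CC1`: 1000 nM
- compound 2, `C[C@H](CO)Nc1nc(C(=O)NCc2ccc(F)cc2)c(O)c2ncccc12`: > 20000 nM

Two compounds have been run in a functional assay on MDA-MB-435 cells (Homo sapiens) for cytotoxicity, read by MTT assay, with a stated time of 72 h; a lower number here means a stronger inhibitor, a higher number a weaker inhibitor. Among the compounds with values here, compound 1 is the only one with a numeric value, and in this assay compound 1 gives 1000 nM. For compound 2 the result is a limit of the assay, > 20000 nM, so no number is known for it; this is the limit of > 20000 nM in this assay, at which 1 of the 2 values shown sits. Compound 1 and compound 2 differ in several places at once, so no single step can be read between them, and nothing beyond their two values should be drawn from the pair.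

Compound 3, `N[C@H]1CC[C@H](Nc2c(C(=O)Nc3ccccc3)nc(Br)c3cccnc23)CC1`, differs from compound 1 by phenyl in place of 4-chlorobenzyl on an amide-type nitrogen. Within the data shown here, with no counted step between measured compounds, the expectation for compound 3 rests on compound 1 alone. Taking the 4-chlorobenzyl away and leaving a plain phenyl on the amide-type nitrogen is expected to cost some activity, a step from compound 1 to compound 3 of about a 3.0-fold higher number from compound 1 to compound 3 (0.48 log units; beyond the scatter) in this assay, modest but beyond the scatter. Compound 3 is therefore estimated at 3000 nM, with a range of 800 nM to 12000 nM.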

Compound 3, half-maximal inhibitory concentration: 1000 nM
Compound 3: middle estimate off by 3.0-fold (0.48 log units), on the high side, within the range that was stated.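

In this assay, within the data shown here, phenyl in place of 4-chlorobenzyl on the amide-type nitrogen gives no change at the digits printed from compound 1 to compound 3 (within the scatter) as the first step that can be read at a single place. With the rest of the core of compound 1 held fixed, this position therefore takes the shorter anilino form as well as the (4-chlorobenzyl)amino form, with no difference that can be told apart in this assay, so neither the chlorine nor the carbon linking the ring to the nitrogen is shown to be needed for the activity seen here. No measured property among the data shown bears on this result, and no cause can be assigned to it.

As far as these compounds go, the chlorine and the linking carbon leave together in this step, so their separate contributions stay open, and an unsubstituted benzyl or a 4-chlorophenyl on the same nitrogen would pull them apart. From the compounds shown here alone, how far the position tolerates change also stays open, for instance with a longer chain such as 2-phenylethyl or with a group carrying an amine or a carboxylic acid.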